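The source may hold more compounds than are shown below. What is called first, only, known or untested is meant among the compounds shown, and "the series" means these compounds.

Compound 3 `N#CCSc1nc(-c2ccncc2)c(-c2ccc(F)cc2)[nH]1` has only a limit in a functional assay (Homo sapiens) for inhibition (a lower number here means a stronger inhibitor, a higher number a weaker inhibitor), < 100 nM, and not a number. Two close analogues have measured values: compound 1 `Fc1ccc(-c2[nH]c(SCCc3ccccc3)nc2-c2ccncc2)cc1` gives 640 nM, and compound 2 `Fc1ccc(-c2[nH]c(SCC3CCCCC3)nc2-c2ccncc2)cc1` gives 240 nM.

The next change, to compound 4 `Fc1ccc(-c2[nH]c(CCc3ccccc3)nc2-c2ccncc2)cc1`, puts phenethyl in place of (cyanomethyl)sulfanyl on an aromatic carbon.

For the measured compounds named here, three measured steps bear on this, all made on the saturated chain carbon bound to sulfur. The closest guide, read in reverse, is an at least 6.4-fold lower number from compound 1 to compound 3 (0.80 log units; beyond the scatter), where cyano replaces benzyl. an at least 2.4-fold lower number from compound 2 to compound 3 (0.38 log units; beyond the scatter) points the same way, and both steps are beyond the scatter, though each is only a bound. a 2.7-fold lower number from compound 1 to compound 2 (0.43 log units; beyond the scatter) shows that the number also shifts modestly with the ring carried at the chain end. Going by the values given here, no measured step removes the sulfur, so that part of the change remains uncovered and the estimate must stay wide.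

Since phenethyl brings in a six-membered aromatic ring of carbon only, a modest move to a higher number is expected, and the estimate is an at least 4.0-fold higher number from compound 3 to compound 4 (0.60 log units; beyond the scatter). For compound 4 the expected value in this assay is 400 nM, with an estimated range of 100 nM to 1500 nM.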

Compound 4, half-maximal inhibitory concentration: 140 nM
Compound 4: the middle estimate sits 2.9-fold (0.46 log units) above what was measured; the measured number falls inside the stated range.
By their numbers in this assay, from the lowest: compounds 4 and 2 (each within the scatter of the next); then compound 1. At a limit, below all of these: compound 3.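

In this assay, for the compounds shown here, the step of a 4.6-fold lower number from compound 1 to compound 4 (0.66 log units; beyond the scatter) is the first here that takes the sulfur out of the chain on the aromatic carbon between two ring nitrogen atoms, and the chain keeps its phenyl end, so at this position the sulfur is not required for inhibition. The step of a 1.7-fold lower number from compound 2 to compound 4 (0.23 log units; within the scatter) shows that the sulfur-free phenethyl and (cyclohexylmethyl)sulfanyl cannot be told apart here, so this position tolerates quite different chains, with or without sulfur. Compound 3 has a limit and not a number, so the comparison with it yields only a bound, an at least 1.4-fold higher number from compound 3 to compound 4 (0.14 log units; that floor lies within the scatter) and that floor leaves open whether (cyanomethyl)sulfanyl truly outperforms phenethyl: the limit of < 100 nM in this assay, at which 1 of the 4 values shown sits.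

The compounds shown leave open whether removing the sulfur has the same effect on chains ending in cyclohexyl or nitrile, since only the phenyl-ended pair isolates that change. Also open, as far as these compounds go, is how an ether oxygen or an amine nitrogen would compare in place of the sulfur, and whether a longer chain or a terminal carboxylic acid would be accepted at this position.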